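The source may report more compounds than this note shows. Statements on the series, on what has been measured and on what is new or still open speak of the compounds shown alone.

Measured in an ADME assay on MT4 cells (Homo sapiens) for inhibition, read by MTT assay, with a stated time of 5 days; a lower number here means that less compound is tolerated, a higher number that more compound is tolerated:
- compound 1 `N#Cc1ccc(Nc2cc(Oc3c(Cl)cccc3Cl)c([N+](=O)[O-])cn2)cc1`: 27700 nM
- compound 2 `N#Cc1ccc(Nc2cc(Oc3c(Cl)cc(Cl)cc3Cl)c([N+](=O)[O-])cn2)cc1`: 16200 nM

Compound 2 and compound 1 lie within the scatter of each other, so the two numbers do not separate. Compound 3 `N#Cc1ccc(Nc2cc(Oc3c(Cl)cc([N+](=O)[O-])cc3Cl)c([N+](=O)[O-])cn2)cc1` derives from compound 2 by nitro in place of chloro on an aromatic carbon, para to a large group.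

Going by the values given here, one measured step bears on this, a 1.7-fold lower number from compound 1 to compound 2 (0.23 log units; within the scatter). Among the compounds with values here, the chloro brought in by that step is the one that leaves here, though no measured compound carries nitro at this place, so the evidence is thin. Within the data shown here, with only that small step to go on, no shift beyond the scatter is expected in this assay, and the range is kept wide. The expected step is a 1.2-fold lower number from compound 2 to compound 3 (0.06 log units; within the scatter). Compound 3 is estimated at 14000 nM, with an expected range of 5000 nM to 35000 nM.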

Compound 3, half-maximal cytotoxic concentration: 26500 nM
The estimate for compound 3 lay 1.9-fold (0.28 log units) below the measured number; the range from low to high includes it.
By their numbers in this assay, from the lowest: compounds 2, 3 and 1 (each within the scatter of the next).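

In this assay this position, para to a large group, now has three measured substituents: hydrogen, chloro and nitro. Nitro in place of chloro gives a 1.6-fold higher number from compound 2 to compound 3 (0.21 log units; within the scatter) and nitro in place of hydrogen gives a 1.0-fold lower number from compound 1 to compound 3 (0.02 log units; within the scatter) and with both steps within the scatter, compounds 1, 2 and 3 do not separate, whether the group here has one heavy atom or three. Nothing available accounts for this flat picture.

On these data alone, whether the position stays this flat with an amine, a carboxylic acid or a longer chain remains open. Also open, as far as these compounds go, is whether nitro at this place gives the same picture without the two chloro groups, which all three compounds carry.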